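Thioether swap: 2,4-dinitrophenyl for 4-bromobenzyl

The compounds below may be only part of what the source reports. "The series", "measured", "known", "first", "only" and "open" are said of these compounds alone.

Measured in a functional assay on K562 cells (Homo sapiens) for cytotoxicity; a higher number here means a weaker inhibitor, a lower number a stronger inhibitor:
- compound 1 `COC(=O)CNC(=O)C(CSCc1ccc(Br)cc1)NC(=O)CCC(NC(=O)OCc1ccccc1)C(=O)OC`: 16.7 uM
- compound 2 `CCCCOC(=O)CNC(=O)C(CSCc1ccc(Br)cc1)NC(=O)CCC(NC(=O)OCc1ccccc1)C(=O)OCCCC`: 16.7 uM
- compound 3 `COC(=O)CNC(=O)C(CSc1ccc([N+](=O)[O-])cc1[N+](=O)[O-])NC(=O)CCC(NC(=O)OCc1ccccc1)C(=O)OC`: 23.4 uM

Compound 1 and compound 2 differ in their cores; the difference between the two cores is not broken down here, and in this assay compound 2 is level with compound 1 at the digits printed. From compound 1 to compound 3 the change is 2,4-dinitrophenyl in place of 4-bromobenzyl on a sulfur, and it gives a 1.4-fold higher number from compound 1 to compound 3 (0.15 log units; within the scatter).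

Compound 4 `CCCCOC(=O)CNC(=O)C(CSc1ccc([N+](=O)[O-])cc1[N+](=O)[O-])NC(=O)CCC(NC(=O)OCc1ccccc1)C(=O)OCCCC` is not yet measured. It carries the same change on the core of compound 2: 2,4-dinitrophenyl in place of 4-bromobenzyl on a sulfur. The place is the same in both pairs.

The step in this assay is expected to be a 1.4-fold higher number from compound 2 to compound 4 (0.14 log units; within the scatter), beside the earlier one. This rests on the measured pair, where compound 3 gives 23.4 uM against compound 1 at 16.7 uM, and on compound 2 sitting level with compound 1. Compound 4 is therefore estimated at 23 uM, with a range from 12 uM to 45 uM.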

Compound 4, concentration for 50% inhibition: 21.8 uM
Compound 4: the middle estimate sits 1.1-fold (0.02 log units) above what was measured, within the range that was stated.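

In this assay, 2,4-dinitrophenyl in place of 4-bromobenzyl on a sulfur gives a 1.3-fold higher number from compound 2 to compound 4 (0.12 log units; within the scatter). Going by these compounds alone, the two cores show no difference in how the change reads out: the same change on two cores in this assay, a 1.4-fold higher number (0.15 log units; within the scatter) from compound 1 to compound 3 and a 1.3-fold higher number (0.12 log units; within the scatter) from compound 2 to compound 4, 1.1-fold (0.03 log units) apart, within the scatter of two such steps This shows only that the change stays within the scatter on the core of compound 1 and on the core of compound 2; it does not show that a step of real size would carry across, nor does it say anything about cores beyond these two.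

The compounds shown leave open whether a carboxylic acid in place of the esters would move the number beyond the scatter in this assay. The same question stands for an amine on the aromatic ring of the sulfur substituent.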